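Anilino variation on a shared tricyclic core in gastric cancer cells

The source may report more compounds than this note shows. Statements on the series, on what has been measured and on what is new or still open speak of the compounds shown alone.

Measured compounds:
compound 1 `Cc1ccc(NC2=CC(=O)c3nc4n(c3C2=O)[C@H]2OC[C@@H](O)[C@H]2OC4)cc1`, 1420 nM
compound 2 `O=C1C(Nc2cccc(Cl)c2)=CC(=O)c2c1nc1n2[C@H]2OC[C@@H](O)[C@H]2OC1`, 1530 nM

Of the compounds shown here, two have been tested in a functional assay on MGC-803 cells (Homo sapiens) for inhibition, read by sulforhodamine B assay; on this read-out lower numbers stand for stronger inhibition and higher numbers for weaker inhibition. Compound 1 gives 1420 nM and compound 2 gives 1530 nM; the two numbers lie within the usual scatter of each other, so neither can be set apart from the other on these data. Compound 3 `CCOc1ccccc1NC1=CC(=O)c2nc3n(c2C1=O)[C@H]1OC[C@@H](O)[C@H]1OC3` shares the core of compound 1 and differs from it in one place: 2-ethoxyphenyl in place of 4-methylphenyl on an amine nitrogen. Both measured compounds carry a substituted phenyl on the same amine nitrogen and give near-identical numbers, which gives no hint of a large effect of the aryl substituent in this assay. Compound 3 is therefore expected to stay close to compound 1, with a step of a 1.1-fold higher number from compound 1 to compound 3 (0.02 log units; within the scatter) that is not expected to exceed the scatter. The estimate for compound 3 is 1500 nM, with a range from 500 nM to 4500 nM.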

Compound 3, half-maximal inhibitory concentration: 2450 nM
Compound 3: the middle estimate sits 1.6-fold (0.21 log units) below what was measured; low and high end bracket the measured number.
By their numbers in this assay, from the lowest: compounds 1, 2 and 3 (each within the scatter of the next).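

In this assay, putting 2-ethoxyphenyl in place of 4-methylphenyl on the amine nitrogen gives a 1.7-fold higher number from compound 1 to compound 3 (0.24 log units; within the scatter) and so does not separate the two compounds. Going by these compounds alone, this is the first comparison that differs in one place only, and it shows that the larger group, which brings a hydrogen-bond acceptor, leaves the number within the scatter. No measured information bears on this result.

The compounds shown leave open whether a phenyl carrying an amine or a carboxylic acid, or one with a longer chain than ethoxy, would give a step beyond the scatter. They also leave open what happens in this assay when a plain alkyl chain replaces the phenyl on this nitrogen.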